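Swapping a methoxy for an ethyl at the ortho position

The source may hold more compounds than are shown below. What is called first, only, known or untested is meant among the compounds shown, and "the series" means these compounds.

Of the compounds shown here, three sharing one core have been tested in an assay on CHO cells with Alpha-2B adrenergic receptor (Homo sapiens) as the target; a higher number here means a larger maximal response, a lower number a smaller maximal response. Compound 1, with the structure `CC(Oc1ccccc1OC1CC1)C1=NCCN1`, gives 0.6. Compound 2, `CC(=O)c1ccccc1OC(C)C1=NCCN1`, gives 0.6. Compound 3, `COc1ccccc1OC(C)C1=NCCN1`, gives 0.5. Compound 3 sits within the scatter of both others: the change a number 0.10 lower from compound 1 to compound 3 (within the scatter) and the change a number 0.10 lower from compound 2 to compound 3 (within the scatter) are each too small to count, as is the change no change at the digits printed from compound 1 to compound 2 (within the scatter) between the other two.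

The next compound, compound 4, has the structure `CCc1ccccc1OC(C)C1=NCCN1`. Its difference from compound 3 is ethyl in place of methoxy on an aromatic carbon. For the measured compounds named here, the step that bears most directly on this is the one from compound 2 to compound 3, where the group on this same aromatic carbon was exchanged and the maximal response barely moved; the step from compound 1 to compound 3, which altered the group on that oxygen, also stayed within the scatter. Going by the values given here, no measured step shows that this position governs the size of the response, so the expected step of no change at the digits printed from compound 3 to compound 4 (within the scatter) is one within the scatter. For compound 4 the maximal response in this assay is therefore estimated at 0.5, with a likely range from 0.35 to 0.7.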

Compound 4, intrinsic activity: the largest response reached, as a fraction of the reference agonist's: 0.5
The estimate for compound 4 equals the measured number at the digits printed; low and high end bracket the measured number.
By their numbers in this assay, from the lowest: compounds 3, 4, 1 and 2 (each within the scatter of the next).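

Ethyl is the first group on this aromatic carbon with no oxygen atom, whereas methoxy, acetyl and cyclopropyloxy each contain one. Yet in this assay, exchanging methoxy for ethyl, which keeps the count of heavy atoms but removes the hydrogen-bond acceptor, gives no change at the digits printed from compound 3 to compound 4 (within the scatter). The comparisons with the other two groups read the same way, with ethyl in place of acetyl giving a number 0.10 lower from compound 2 to compound 4 (within the scatter) and ethyl in place of cyclopropyloxy giving a number 0.10 lower from compound 1 to compound 4 (within the scatter), so among these four compounds an oxygen in this group is not required for the maximal response to stay within the scatter.

Nothing available explains why the maximal response holds so steady across these four groups. On these data alone, it remains open whether a group of a very different kind on this aromatic carbon, such as an amine, a carboxylic acid or a longer chain like hexyl, would also leave this assay within the scatter, or whether the flat result seen so far would break.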